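The source may hold more compounds than are shown below. What is called first, only, known or untested is meant among the compounds shown, and "the series" means these compounds.

Working notes on the dithiocarbamate series built on the shared core of compound 1 `CCNC(=S)SCC1=CCOC1=O`. In a functional assay on HeLa cells (Homo sapiens) for antiproliferative activity, read by MTT assay, with a stated time of 72 h (on this read-out lower numbers stand for stronger inhibition and higher numbers for weaker inhibition), compound 1 is reported as "not active" (no number reported), so no single number stands for it. Within the data shown here, the only measured number in the set belongs to compound 2 `CN(C)C(=S)SCC1=CCOC1=O`, which in this assay gives 114000 nM, a weak result. Compound 1 and compound 2 differ in more than one place, so nothing is read from their pairing beyond what the two entries themselves show.

The next compound, compound 3 `O=C1OCC=C1CSC(=S)NCc1ccccc1`, differs from compound 1 by one change: phenyl in place of methyl on a saturated chain carbon bound to an amide-type nitrogen. Among the measured compounds shown here, no measured step of this kind exists, so the expected size of the step in this assay is unknown; a step no larger than the scatter of the assay, in either direction, is the working assumption, with a real chance that compound 3 again returns no number. The estimate for compound 3 in this assay is 90000 nM, within 20000 nM to 400000 nM.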

Compound 3, half-maximal inhibitory concentration: 15100 nM
The estimate for compound 3 lay 6.0-fold (0.78 log units) above the measured number; the whole stated range lies above it.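

In this assay, among these compounds, compound 1 gives "not active" (no number reported) and so no step to compound 3 can be read. Nothing at hand bears on a cause for the result of compound 3. The compounds shown leave open what size a single change on the shared core has in this assay and in which direction it goes.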